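The source may report more compounds than this note shows. Statements on the series, on what has been measured and on what is new or still open speak of the compounds shown alone.

Values in an ADME assay on HEp-2 cells (Homo sapiens) for cytotoxicity, read by MTT assay, with a stated time of 72 h; on this read-out lower numbers stand for stronger inhibition and higher numbers for weaker inhibition:
- Compound 1 `COc1ccc(OC)c(C2=C(c3cc(OC)c(OC)c(OC)c3)C(=O)CC2O[SiH2]C(C)(C)C)c1`: 19 ug/mL
- Compound 2 `COC(=O)c1cc(C2=C(c3cc(OC)c(OC)c(OC)c3)C(=O)CC2O[SiH2]C(C)(C)C)ccc1OC`: > 100 ug/mL

Compound 2 sits at the limit of > 100 ug/mL in this assay, at which 1 of the 2 values shown sits, so its place is a limit and not a number. Compound 3 `COc1cc(C2=C(c3cc(C)c(OC)c(C)c3)C(O[SiH2]C(C)(C)C)CC2=O)cc(OC)c1OC` carries 4-methoxy-3,5-dimethylphenyl in place of 4-methoxy-3-(methoxycarbonyl)phenyl on a double-bonded ring carbon. Within the data shown here, the one measured step at this carbon, an at least 5.2-fold higher number from compound 1 to compound 2 (0.72 log units; beyond the scatter), brought in the group that compound 3 gives up. Among the measured compounds shown here, a reversal of similar size is therefore expected in this assay, towards a lower number, though only one step supports this. The expected change is an at least 3.3-fold lower number from compound 2 to compound 3 (0.52 log units; beyond the scatter). For compound 3 the estimate is 30 ug/mL, with an expected range of 9 ug/mL to 100 ug/mL.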

Compound 3, half-maximal inhibitory concentration: 26 ug/mL
Beside the measured number, compound 3's estimate is 1.2-fold (0.06 log units) above it, within the range that was stated.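

In this assay, the 4-methoxy-3,5-dimethylphenyl group on this double-bonded ring carbon gives an at least 3.8-fold lower number from compound 2 to compound 3 (0.58 log units; beyond the scatter). Replacing 2,5-dimethoxyphenyl with the same group gives a 1.4-fold higher number from compound 1 to compound 3 (0.14 log units; within the scatter), so these two substitution patterns are not separated, and compound 2 goes against any reading that this carbon accepts every substituted phenyl group. The size of the first step remains bounded on one side only, as compound 2 is a limit and not a number: the limit of > 100 ug/mL in this assay, at which 1 of the 3 values shown sits.

As far as these compounds go, whether the weaker reading of compound 2 belongs to the methoxycarbonyl group itself remains open. Also open, from the compounds shown here alone, is how a carboxylic acid or an amine in its place would read.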